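Adding a Second Trifluoromethyl to the Amide Aryl

The source may report more compounds than this note shows. Statements on the series, on what has been measured and on what is new or still open speak of the compounds shown alone.

In a functional assay on UO-31 cells (Homo sapiens) for inhibition, read by sulforhodamine B assay, with a stated time of 48 h, tested at 10 uM (on this read-out higher numbers stand for a weaker effect at the one concentration tested and lower numbers for a stronger effect), three compounds have been measured:
compound 1 `COc1cc(Cl)cc(-c2nn(-c3cccc(NC(=O)Nc4ccc(Cl)c(C(F)(F)F)c4)c3)cc2-c2ccncc2)c1` gives 11.1%
compound 2 `COc1cc(Cl)cc(-c2nn(-c3cccc(NC(=O)Nc4cccc(C(F)(F)F)c4)c3)cc2-c2ccncc2)c1` gives -4.59%
compound 3 `COc1cc(Cl)cc(-c2nn(-c3cccc(NC(=O)c4cccc(C(F)(F)F)c4)c3)cc2-c2ccncc2)c1` gives 37.3%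

Compound 3 stands highest of the three, meaning weakest: the change is a number 26.2 percentage points higher from compound 1 to compound 3 (beyond the scatter) and a number 41.9 percentage points higher from compound 2 to compound 3 (beyond the scatter), both beyond the scatter. Compound 4 `COc1cc(Cl)cc(-c2nn(-c3cccc(NC(=O)c4cc(C(F)(F)F)cc(C(F)(F)F)c4)c3)cc2-c2ccncc2)c1` is not yet measured; it differs from compound 3 by trifluoromethyl in place of hydrogen on an aromatic carbon, entering meta to a trifluoromethyl group. Among the compounds with values here, no measured step adds a trifluoromethyl. The nearest comparison is a number 15.7 percentage points lower from compound 1 to compound 2 (beyond the scatter), where a halogen left an aromatic ring and the number fell modestly; so adding one is expected to move the number little, if anything slightly higher. Compound 4 is therefore expected to give 42%, within 18% to 66%, a step of a number 4.7 percentage points higher from compound 3 to compound 4 (within the scatter) from compound 3.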

Compound 4, a percentage reported as activity, at one concentration (the size of the read-out at that concentration, not a potency): 54.3%
Estimate against measurement, compound 4: 12.3 percentage points below; the measured number falls inside the stated range.
By their numbers in this assay, from the lowest: compound 2; then compound 1; then compound 3; then compound 4.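

In this assay the added trifluoromethyl gives a number 17 percentage points higher from compound 3 to compound 4 (beyond the scatter) and so shows that this ring position, meta to a trifluoromethyl group, is not neutral: a second such group here goes with a weaker effect at the one concentration tested. Within the data shown here, this is the first measured step in which a group is added to that ring. No measurement offers an explanation for this change. As far as these compounds go, whether a smaller group at this position, such as methyl or an amine, would give a number nearer that of compound 3 remains open.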